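The compounds below may be only part of what the source reports. "The series", "measured", "known", "first", "only" and "open" are said of these compounds alone.

Measured so far:
Compound 1 `CC(C)N/C(=N\c1nccn1C(C)(C)C)Nc1ccc(Cl)c(Cl)c1` gives 0.15 h
Compound 2 `CC(C)(C)n1ccnc1/N=C(\N)Nc1ccc(Cl)c(Cl)c1` gives 0.8 h
Compound 3 `CC(C)N1CCN=C1/N=C(\N)Nc1ccc(Cl)c(Cl)c1` gives > 1 h, a limit of the assay

In an in vitro ADME assay on microsomes from liver (Mus musculus) for metabolic stability, read by LC-MS, tested at 1 uM (on this read-out lower numbers stand for a shorter-lived compound and higher numbers for a longer-lived compound), compound 2 and compound 1 share a core and differ by isopropyl in place of hydrogen on an amine nitrogen. That change produced a 5.3-fold lower number from compound 2 to compound 1 (0.73 log units; beyond the scatter). For compound 3 the assay reports only a limit, > 1 h; it sits at the limit of > 1 h in this assay, at which 1 of the 3 values shown sits. How the core of compound 3 differs from the core of compound 2 is not broken down here.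

Compound 4 `CC(C)N/C(=N\C1=NCCN1C(C)C)Nc1ccc(Cl)c(Cl)c1` is not yet measured. It differs from compound 3 by isopropyl in place of hydrogen on an amine nitrogen, the same change as from compound 2 to compound 1, made at the same kind of place. From compound 3 to compound 4 a step of an at least 3.3-fold lower number from compound 3 to compound 4 (0.52 log units; beyond the scatter) is expected, resting on the step of a 5.3-fold lower number from compound 2 to compound 1 (0.73 log units; beyond the scatter) and on compound 3 giving only a limit. Compound 4 is therefore estimated at 0.3 h, between 0.1 h and 1 h.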

Compound 4, half-life: 0.227 h
Compound 4: middle estimate off by 1.3-fold (0.12 log units), on the high side, and the stated range covers the measured number.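

Carried to the core of compound 3, isopropyl in place of hydrogen on an amine nitrogen gave an at least 4.4-fold lower number from compound 3 to compound 4 (0.64 log units; beyond the scatter) in this assay. The change points the same way on both cores shown: the same change on two cores in this assay, a 5.3-fold lower number (0.73 log units; beyond the scatter) from compound 2 to compound 1 and an at least 4.4-fold lower number (0.64 log units; beyond the scatter) from compound 3 to compound 4; the limit leaves it open whether they differ Compound 3 gives > 1 h, which is a limit of the assay, so the two cores show that the direction carries over but not that the size does.

The compounds shown leave open whether methyl or ethyl on the same amine nitrogen would lower the number as isopropyl does. They also leave open whether the step would hold on any core beyond these two.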